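Heteroaryl thioether variation in a difluorophenyl urea series

This account rests on a few compounds, and the source may have more. Where it says the series, first, only, none or still open, it means among the compounds named here.

Measured so far:
compound 1 `CCCCCCN(CCCCCSc1nc2ccc[nH]c-2n1)C(=O)Nc1ccc(F)cc1F` — 5470 nM
compound 2 `CCCCCCCN(CCCCCSc1nc(O)c2ccccc2n1)C(=O)Nc1ccc(F)cc1F` — 11000 nM

In an assay on cells (Macrophage) for inhibition of sterol O-acyltransferase 1 (Mus musculus) (a higher number here means a weaker inhibitor, a lower number a stronger inhibitor), compound 2 gives 11000 nM, and compound 1 gives 5470 nM; the gap between the two lies within the scatter, so neither is set apart from the other. Compound 3 `CCCCCCCN(CCCCCSc1n[nH]c(-c2ccccc2)n1)C(=O)Nc1ccc(F)cc1F` differs from compound 2 by 5-phenyl-1H-1,2,4-triazol-3-yl in place of 4-hydroxyquinazolin-2-yl on a sulfur. Going by the values given here, no measured pair shows this change, and the two numbers in hand give no direction for it. The step from compound 2 to compound 3 is therefore expected to be a 1.2-fold lower number from compound 2 to compound 3 (0.09 log units; within the scatter), none beyond the scatter. Compound 3 is estimated at 9000 nM, with a range from 3000 nM to 27000 nM.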

Compound 3, half-maximal inhibitory concentration in the sterol O-acyltransferase 1 assay: 4180 nM
Compound 3: the middle estimate sits 2.2-fold (0.33 log units) above what was measured; the range from low to high includes it.
By their numbers in the sterol O-acyltransferase 1 assay, from the lowest: compounds 3, 1 and 2 (each within the scatter of the next, the first and the last beyond it).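

Going by these compounds alone, on the sulfur, in the sterol O-acyltransferase 1 assay, 5-phenyl-1H-1,2,4-triazol-3-yl in place of 4-hydroxyquinazolin-2-yl gives a 2.6-fold lower number from compound 2 to compound 3 (0.42 log units; beyond the scatter), the first readable step at this position, since compounds 1 and 2 differ in more than one place. The heavy-atom count of the group stays the same across the change, yet the number moves. In a physicochemical assay for lipophilicity (on this read-out higher numbers stand for higher lipophilicity and lower numbers for lower lipophilicity), compound 2 gives 6.17, and compound 3 gives 6.78. Lipophilicity rises with this step, so it may account for part of the gain: the measured partition coefficient of compound 2, 6.17, and of compound 3, 6.78, a number 0.61 log units higher (beyond the scatter)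

On these data alone, whether the gain can be separated from lipophilicity stays open. Also open, as far as these compounds go, is how an amine or a carboxylic acid in place of the phenyl group would read.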